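The source may report more compounds than this note shows. Statements on the series, on what has been measured and on what is new or still open speak of the compounds shown alone.

Measured so far:
- compound 1, `Cc1cccc(/C(N)=N/NC(=S)N2CCCCC2)n1`: 83.5%
- compound 2, `Cc1ccnc(/C(N)=N/NC(=S)N2CCOCC2)c1`: 49.1%

Compound 1 gives the higher of these two numbers in a functional assay on HeLa cells (Homo sapiens) for cytotoxicity, read by MTT assay, with a stated time of 72 h, tested at 10 uM (on this read-out higher numbers stand for more inhibition of growth at the one concentration tested and lower numbers for less inhibition of growth), and compound 2 stands a good way below it, further than the usual scatter of this kind of measurement. Among the measured compounds shown here, compound 2 differs from compound 1 in more than one place, so the two values show only that one compound is more active than the other, not which part of the structure is responsible.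

The piece now follows one single change from compound 1. Compound 3, `Cc1cccc(/C(N)=N/NC(=S)N2CCOCC2)n1`, keeps everything of compound 1 except that a (morpholin-4-yl in place of piperidin-1-yl on a thiocarbonyl carbon). The ring that enters carries an oxygen where the leaving ring carries a carbon.

Nothing measured here isolates this change alone. Compound 2 does carry the morpholin-4-yl ring and gives the lower value, so a decrease is expected for compound 3 in this assay, of moderate size: the step of a number 21.5 percentage points lower from compound 1 to compound 3 (beyond the scatter) is the estimate. For compound 3 the expected value is 62%, with a range from 42% to 80%.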

Compound 3, percent growth inhibition at one concentration: 85.4%
Compound 3: middle estimate off by 23.4 percentage points, on the low side; measured number above the stated range.
By their numbers in this assay, from the lowest: compound 2; then compounds 1 and 3 (each within the scatter of the next).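

In this assay, morpholin-4-yl in place of piperidin-1-yl on a thiocarbonyl carbon gives a number 1.9 percentage points higher from compound 1 to compound 3 (within the scatter). Among the compounds shown here, this is the first comparison in which only this ring differs, and on the core of compound 1 the two rings cannot be told apart in this read-out, even though the entering ring carries an oxygen and a hydrogen-bond acceptor that the leaving ring lacks. The morpholin-4-yl ring alone therefore does not go with a low number: compound 3 gives 85.4%, while compound 2, which carries the same ring, gives 49.1%.

No data here explain why the two rings give such closely matching numbers. On these data alone, it remains open whether other groups on the thiocarbonyl carbon, such as a 4-methylpiperazin-1-yl ring or an open-chain dimethylamino group, would match these two rings, and whether piperidin-1-yl and morpholin-4-yl would also match on the core of compound 2.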